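A few compounds are considered here, and "the series" means these few. Any claim that something is new, unique, unknown or untested is made for them only; others in the source may bear on it.

Measured compounds, half-maximal inhibitory concentration in a functional assay on MDA-MB-231 cells (Homo sapiens) for antiproliferative activity, read by MTT assay, with a stated time of 72 h; on this read-out higher numbers stand for weaker inhibition and lower numbers for stronger inhibition:
- compound 1 `COc1cc(CCc2cccc(Cl)c2Cl)cc(OC)c1O`: 6870 nM
- compound 2 `COc1cc(CCc2cccc(F)c2)cc(OC)c1O`: > 25000 nM (a limit of the assay, not a number)
- compound 3 `COc1ccc(CCc2ccccn2)cc1OC`: 10500 nM

Compound 1 gives the lowest of the two numbers in this assay, and compound 3 sits within the scatter of it, so no order between those two can be read. For the measured compounds named here, for compound 2 only a limit is reported, as noted in the limit of > 25000 nM in this assay, at which 1 of the 3 values shown sits; it is the one value of the three that is not a number.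

Compound 4 `COc1cc(CCc2ccccc2Cl)cc(OC)c1O` is not yet measured. It differs from compound 1 by hydrogen in place of chloro on an aromatic carbon. Going by the values given here, no measured pair shows such a step on its own. Among the compounds with values here, the only compound with a single halogen on that ring is compound 2, and its value is a limit, which points toward a weaker result for compound 4 than for compound 1 rather than a stronger one. The step from compound 1 to compound 4 is therefore expected to be a 1.9-fold higher number from compound 1 to compound 4 (0.28 log units; within the scatter), toward weaker inhibition. Compound 4 is estimated at 13000 nM in this assay, with a range from 5500 nM to 30000 nM.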

Compound 4, half-maximal inhibitory concentration: 21100 nM
Beside the measured number, compound 4's estimate is 1.6-fold (0.21 log units) below it; the range from low to high includes it.
By their numbers in this assay, from the lowest: compounds 1, 3 and 4 (each within the scatter of the next, the first and the last beyond it). At a limit, above all of these: compound 2.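

Hydrogen in place of chloro on this aromatic carbon gives a 3.1-fold higher number from compound 1 to compound 4 (0.49 log units; beyond the scatter) in this assay and so provides the first single-place step in the series, one that lies beyond the scatter. At this position, ortho to a chloro group and meta to a large group, the chloro group of compound 1 therefore carries a modest share of the activity seen in this assay. Compound 2 differs in more than one place and carries a limit of the assay, not a number, so it adds nothing to this step: the limit of > 25000 nM in this assay, at which 1 of the 4 values shown sits.

For the compounds shown here, the contribution of the remaining chloro group of compound 4 stays open, since no step removes or moves it. Also open, on these data alone, is how an amine or a carboxylic acid on the same aromatic carbon would compare with hydrogen and chloro.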